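A few compounds are considered here, and "the series" means these few. Any claim that something is new, unique, unknown or untested is made for them only; others in the source may bear on it.

Compound 1 `Fc1cccc(F)c1Cn1ccc2nc(-c3c(F)cccc3F)nc-2c1` is the starting point of this step. In an ADME assay on MDBK cells (Bos taurus) for cytotoxicity (on this read-out higher numbers stand for lower toxicity in this test and lower numbers for higher toxicity in this test), compound 1 gives > 100000 nM, which is a limit of the assay and not a number. Compound 2 `Fc1cccc(F)c1-c1nc2ccn(Cc3ccccc3)cc-2n1` gives > 100000 nM, again a limit and not a number. What the two compounds share is the limit of > 100000 nM in this assay, at which 2 of the 2 values shown sit. Among the compounds with values here, the one measured step that bears on the change is a step that the two limits leave unreadable from compound 1 to compound 2, so it offers no size to carry over.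

Compound 3 `Fc1cccc(F)c1Cn1ccc2nc(-c3ccccc3)nc-2c1` has not yet been measured. Its difference from compound 1 is phenyl in place of 2,6-difluorophenyl on an aromatic carbon, here on a five-membered aromatic ring with 2 nitrogen, between two ring nitrogen atoms. With compound 2 at > 100000 nM, the data hold no measured number, only a limit. No step beyond the scatter is therefore expected in this assay, in either direction, and a further limit is the likeliest report. The estimated change is a number no higher from compound 1 to compound 3 (the limit leaves the size open). For compound 3 the expected value is 100000 nM, with an estimated range from 50000 nM to 200000 nM.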

Compound 3, half-maximal cytotoxic concentration: > 100000 nM
Compound 3 was reported as a limit; the forecaster's own chance of this, stated with the estimate: 85%; the middle value lies on the limit itself.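

In this assay, within the data shown here, compound 3 gives > 100000 nM, a limit of the assay and not a number, so no step from compound 1 to compound 3 can be read. The compounds shown leave open what number compound 1, compound 2 and compound 3 would each give, and whether phenyl in place of 2,6-difluorophenyl changes that number at all.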